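The compounds below may be only part of what the source reports. "The series", "measured", "known", "first", "only" and "open" are said of these compounds alone.

Of the compounds shown here, two sharing the same core have been measured in an assay on isolated protein for inhibition of Flap endonuclease 1 (Homo sapiens); on this read-out lower numbers stand for stronger inhibition and higher numbers for weaker inhibition. Compound 1, `O=C(O)C(=O)CC(=O)c1ccc(-c2ccccc2Cl)o1`, carries a chlorinated phenyl ring on its five-membered ring; in this assay compound 1 gives 12200 nM. Compound 2, `O=C(O)C(=O)CC(=O)c1cccs1`, has a bare five-membered sulfur ring instead; in this assay compound 2 gives 10100 nM. The two numbers lie within the usual scatter of each other, so on the numbers shown compound 2 stands level with compound 1, and neither can be called the stronger inhibitor.

Compound 3, `O=C(O)C(=O)CC(=O)c1ccc(C(F)(F)F)s1`, keeps the core of compound 2 and differs from it in one place: trifluoromethyl in place of hydrogen on an aromatic carbon. For the measured compounds named here, no measured pair in this set shows what such a change does, so there is no comparison to lean on. Given that, the step from compound 2 to compound 3 is expected to be small, a 1.3-fold lower number from compound 2 to compound 3 (0.10 log units; within the scatter), leaning if anything toward a slightly lower number but staying close to the scatter. For compound 3 the expected value in this assay is estimated at 8000 nM, with a range from 3000 nM to 25000 nM.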

Compound 3, half-maximal inhibitory concentration: 1520 nM
Compound 3: the middle estimate sits 5.3-fold (0.72 log units) above what was measured; the whole stated range lies above it.
By their numbers in this assay, from the lowest: compound 3; then compounds 2 and 1 (each within the scatter of the next).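

In this assay, trifluoromethyl in place of hydrogen on an aromatic carbon gives a 6.6-fold lower number from compound 2 to compound 3 (0.82 log units; beyond the scatter), a step beyond the scatter, so this place on the five-membered aromatic ring with 1 sulfur, next to the ring sulfur, is one where a change of group can shift the number clearly. For the compounds shown here, compound 1 and compound 2 differ in more than one place, so their pair could not isolate any single change, and this is the first step in the set that ties a shift in the number to one group at one position. Nothing shown here gives a measured reason for the shift, so it stands as an observation without an explanation.

With trifluoromethyl as the only group shown at this position, it stays open whether the gain belongs to that group or would also appear with a methyl, a chlorine atom, a nitrile or an amine in the same place. On these data alone, it also stays open whether the same change would give a step of similar size on the core of compound 1.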